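Series notes: swapping the ketone aryl group of compound 1

This account rests on a few compounds, and the source may have more. Where it says the series, first, only, none or still open, it means among the compounds named here.

Going by the values given here, compound 1 `O=C(/C=C/c1ccc2c(c1)B(O)OC2)c1cccnc1` stands at the top of the two numbers measured so far in a toxicity assay on WI-38 cells (Homo sapiens) for cytotoxicity, read by MTT assay, with a stated time of 48 h; a higher number here means a weaker inhibitor, a lower number a stronger inhibitor: compound 1 gives 76200 nM, the highest value in the set. The nearest entry is compound 2 `Cc1ccc(C(=O)/C=C/c2ccc3c(c2)B(O)OC3)cc1C`, which in this assay gives 22000 nM; the gap between compound 1 and compound 2 lies beyond the scatter, so compound 1 is the weaker inhibitor of the two.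

Compound 3 `O=C(/C=C/c1ccc2c(c1)B(O)OC2)c1cccc(O)c1` has not yet been measured. It differs from compound 1 at a single place: 3-hydroxyphenyl in place of pyridin-3-yl on a carbonyl carbon. Among the compounds with values here, no measured pair in the set carries this same change, so there is no directly comparable step to lean on. What the numbers do show is that compound 2, whose carbonyl carbon also carries a carbon-only six-membered ring, sits well under compound 1.

On that basis the step of a 1.9-fold lower number from compound 1 to compound 3 (0.28 log units; within the scatter) is expected to be a moderate lowering of the number, of a size that should clear the scatter but need not reach the level of compound 2. Compound 3 is accordingly estimated at 40000 nM, with a plausible range from 15000 nM to 100000 nM.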

Compound 3, half-maximal inhibitory concentration: 26400 nM
For compound 3 the middle estimate is 1.5-fold (0.18 log units) above the measured one; the range from low to high includes it.
By their numbers in this assay, from the lowest: compounds 2 and 3 (each within the scatter of the next); then compound 1.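

In this assay, going by these compounds alone, the exchange of pyridin-3-yl for 3-hydroxyphenyl on a carbonyl carbon gives a 2.9-fold lower number from compound 1 to compound 3 (0.46 log units; beyond the scatter) and is the first single-place step, showing that the number at this position moves with the identity of the ring. The two compounds with a carbon-only ring at this place, compound 3 at 26400 nM and compound 2 at 22000 nM, lie within the scatter of each other and both sit under compound 1, so among these three compounds no entry goes against the link between a carbon-only ring and the lower number, although three compounds are a thin basis for it. No measured evidence bears on what lies behind the step.

The step changes two things at once, the ring nitrogen leaving and the hydroxyl entering, and the compounds shown leave open which of the two goes with the lower number. Unsubstituted phenyl or 3-aminophenyl on the same carbonyl carbon would bear directly on that question.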